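Compound 1 to compound 4: notes on the side chain

The source may report more compounds than this note shows. Statements on the series, on what has been measured and on what is new or still open speak of the compounds shown alone.

For the measured compounds named here, in an ADME assay on HepG2 cells (Homo sapiens) for cytotoxicity, read by MTT assay, with a stated time of 24 h (a lower number here means that less compound is tolerated, a higher number that more compound is tolerated), compound 1 (`OCCCc1cn(-c2ccnc3cc(Cl)ccc23)nn1`) gives 151000 nM as the only true number in this small set. Compound 2 (`CCc1ccc(C(=O)OCCCc2cn(-c3ccnc4cc(Cl)ccc34)nn2)cc1`) reads > 2550000 nM and this value is a limit. Compound 3 (`Cc1ccc(C(=O)OCCCc2cn(-c3ccnc4cc(Cl)ccc34)nn2)cc1`) reads > 2460000 nM and this value is also a limit. Compound 1 is thus the least tolerated of the three.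

Placing (4-ethylphenyl)carbonyl on the oxygen of compound 1 gives a large step, an at least 16-fold higher number from compound 1 to compound 2 (1.22 log units; beyond the scatter) in size. Placing (4-methylphenyl)carbonyl there gives another large step, an at least 16-fold higher number from compound 1 to compound 3 (1.21 log units; beyond the scatter) in size.

Compound 4 (`CN(C)Cc1cn(-c2ccnc3cc(Cl)ccc23)nn1`) has dimethylamino in place of 2-hydroxyethyl on a saturated chain carbon bound to an aromatic carbon, and dimethylamino in place of 2-hydroxyethyl on a saturated chain carbon bound to an aromatic carbon gives the count of that change. Both measured steps act on the oxygen that leaves here, but neither brings in dimethylamino, so their large size is not carried over. The expectation therefore starts from compound 1 at 151000 nM with no step beyond the scatter in this assay and only a slight lean towards a higher number. The expected step is a 1.3-fold higher number from compound 1 to compound 4 (0.12 log units; within the scatter) on this reasoning. The estimate for compound 4 is 200000 nM with an expected range of 50000 nM to 900000 nM in this measurement.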

Compound 4, half-maximal cytotoxic concentration: 1850000 nM
The estimate for compound 4 lay 9.3-fold (0.97 log units) below the measured number; the whole stated range lies below it.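

In this assay, the change on a saturated chain carbon bound to an aromatic carbon gives a large step without any aromatic ester: dimethylamino in place of 2-hydroxyethyl gives a 12-fold higher number from compound 1 to compound 4 (1.09 log units; beyond the scatter). For the compounds shown here, the group that enters matches the group that leaves at 3 heavy atoms each, and, like the esters in compound 2 and compound 3, compound 4 has no hydroxyl hydrogen; within this small set, all three stand higher than compound 1, and no compound goes against this. No measured property at hand accounts for the step.

On these data alone, the step from compound 2 to compound 3 cannot be read, and the difference between the ethyl and methyl groups on their aromatic esters stays open. A methyl ether, a primary amine or a longer chain ending in dimethylamino at this place could separate the loss of the hydroxyl hydrogen from the entry of the nitrogen.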